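Swapping nitro for amino on the phenyl ring of a xanthine

The source may report more compounds than this note shows. Statements on the series, on what has been measured and on what is new or still open speak of the compounds shown alone.

Compound 1, `Cn1c(=O)c2nc(-c3cccc(F)c3)[nH]c2n(C)c1=O`, was tested in an assay for binding affinity to adenosine receptor A1 (Bos taurus) (on this read-out higher numbers stand for weaker inhibition and lower numbers for stronger inhibition), and gave 4 nM. Compound 2, `Cn1c(=O)c2nc(-c3cccc([N+](=O)[O-])c3)[nH]c2n(C)c1=O`, differs from it only in the group on the pendant phenyl ring; in this assay compound 2 gives 50 nM. That single exchange produced a 13-fold higher number from compound 1 to compound 2 (1.10 log units; beyond the scatter). Among the two numbers available, compound 2 therefore stands as the highest, with compound 1 as its only neighbour, a step well beyond the usual scatter.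

Compound 3, `Cn1c(=O)c2nc(-c3cccc(N)c3)[nH]c2n(C)c1=O`, has not yet been measured. Relative to compound 2, the change is amino in place of nitro on an aromatic carbon. Going by the values given here, no measured step involves an amino group, so the only guidance is the step from compound 1 to compound 2, in which introducing the nitro group raised the number sharply. Taking that nitro group away again might undo part of that rise, but the amino group is new territory here, and the outcome is uncertain.

For compound 3 the number is estimated at 15 nM, within 4 nM to 60 nM, meaning an expected 3.3-fold lower number from compound 2 to compound 3 (0.52 log units; beyond the scatter).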

Compound 3, half-maximal inhibitory concentration: 10 nM
For compound 3 the middle estimate is 1.5-fold (0.18 log units) above the measured one; the range from low to high includes it.
By their numbers in this assay, from the lowest: compound 1; then compound 3; then compound 2.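

At this place on the six-membered aromatic ring, the nitro group can be exchanged with a clear gain in this assay: amino in place of nitro gives a 5.0-fold lower number from compound 2 to compound 3 (0.70 log units; beyond the scatter), so part of the rise seen with nitro is taken back. The same amino group, set against fluoro, still gives a 2.5-fold higher number from compound 1 to compound 3 (0.40 log units; beyond the scatter), which places compound 3 between the other two compounds, with every step beyond the usual scatter and fluoro keeping the lowest number of the three groups. No measurement available here explains why the number moves with these groups.

The compounds shown leave open where a chloro, methoxy or carboxylic acid group would fall on this scale at the same place, and whether an acetamide built on the amino nitrogen would stay close to compound 3 or move away from it. They also leave open whether the order of fluoro, amino and nitro would hold with these groups placed elsewhere on the ring.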